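Methylsulfanyl for propylamino on the shared core: cytotoxicity

The source may hold more compounds than are shown below. What is called first, only, known or untested is meant among the compounds shown, and "the series" means these compounds.

Compound 1, `CCCNc1nc(N)nc2c1ncn2/C=C1/CC1(CO)CO`, gives > 24000 nM in an ADME assay on Akata cells (Homo sapiens) for cytotoxicity, with a stated time of 7 days (a higher number here means that more compound is tolerated, a lower number that less compound is tolerated), which is a limit of the assay.
Compound 2, `CCCOc1nc(N)nc2c1ncn2/C=C1/CC1(CO)CO`, gives > 20000 nM in this assay, again a limit of the assay.
Compound 3, `CCCCCOc1nc(N)nc2c1ncn2/C=C1/CC1(CO)CO`, gives > 20000 nM in this assay, also a limit of the assay.

Compound 1 therefore stands only at a limit; two of the three values sit at the limit of > 20000 nM in this assay, at which 2 of the 3 values shown sit, and one at the limit of > 24000 nM in this assay, at which 1 of the 3 values shown sits. The change to compound 4, `CSc1nc(N)nc2c1ncn2/C=C1/CC1(CO)CO`, is methylsulfanyl in place of propylamino on an aromatic carbon. The measured steps a step that the two limits leave unreadable from compound 1 to compound 2, a step that the two limits leave unreadable from compound 1 to compound 3 and a step that the two limits leave unreadable from compound 2 to compound 3 are all unreadable, so they give no size and no direction. Compound 4 is accordingly expected to show a step that the limit leaves unreadable from compound 1 to compound 4, most likely another limit. Compound 4 is estimated at 25000 nM, within 10000 nM to 100000 nM.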

Compound 4, half-maximal cytotoxic concentration: > 20000 nM
Compound 4 ended at the assay's limit; the forecaster's own chance of this, stated with the estimate: 80%; the middle value is on the limit's open side.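

Compound 4 also ends at a limit of the assay, so its steps from compound 1, compound 2 and compound 3 cannot be read. The compounds shown leave open whether these groups on the aromatic carbon differ at all in this assay.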